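Pyridin-2-yl in place of pyrimidin-2-yl: working notes

The source may hold more compounds than are shown below. What is called first, only, known or untested is meant among the compounds shown, and "the series" means these compounds.

Measured so far in a functional assay on L5178Y cells (Mus musculus) for antiproliferative activity, read by MTT assay; a lower number here means a stronger inhibitor, a higher number a weaker inhibitor
- compound 1 `CC(=O)c1ccc(OCCCCN2CCN(c3cccnc3)CC2)cc1` gives 24.2 nM
- compound 2 `CC(=O)c1ccc(OCCCCN2CCN(c3ncccn3)CC2)cc1` gives 31.6 nM
- compound 3 `CC(C)(C)c1ccc(OCCCCN2CCN(c3ncccn3)CC2)cc1` gives 11.3 nM

Compound 2 stands at the high end of these three numbers. Two measured steps frame it, a 1.3-fold higher number from compound 1 to compound 2 (0.12 log units; within the scatter) and a 2.8-fold lower number from compound 2 to compound 3 (0.45 log units; beyond the scatter), so only the second separates it clearly from a neighbour.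

The next compound is compound 4 `CC(=O)c1ccc(OCCCCN2CCN(c3ccccn3)CC2)cc1`, with pyridin-2-yl in place of pyrimidin-2-yl on an amine nitrogen in a ring. The counted difference is pyridin-2-yl in place of pyrimidin-2-yl on an amine nitrogen in a ring and the rest of the structure stays the same.

Within the data shown here, the closest precedent is the exchange at this same place, a 1.3-fold higher number from compound 1 to compound 2 (0.12 log units; within the scatter), which stayed small. The tert-butyl exchange, a 2.8-fold lower number from compound 2 to compound 3 (0.45 log units; beyond the scatter), lies on an aromatic carbon elsewhere and bears little on this change. Among the measured compounds shown here, no measured compound yet carries pyridin-2-yl, so this remains an inference from one step.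

No step beyond the scatter is therefore expected in this assay. The expected change is a 1.2-fold lower number from compound 2 to compound 4 (0.07 log units; within the scatter), a shift too small to read. Compound 4 is estimated at 27 nM, with an expected range of 13 nM to 52 nM and the measurement still to come.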

Compound 4, half-maximal inhibitory concentration: 24.1 nM
For compound 4 the middle estimate is 1.1-fold (0.05 log units) above the measured one; low and high end bracket the measured number.
By their numbers in this assay, from the lowest: compound 3; then compounds 4, 1 and 2 (each within the scatter of the next).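

Three groups can now be compared on the amine nitrogen in a ring with acetyl held constant, and this assay shows a 1.3-fold lower number from compound 2 to compound 4 (0.12 log units; within the scatter) and a 1.0-fold lower number from compound 1 to compound 4 (0.00 log units; within the scatter). Neither pyrimidin-2-yl to pyridin-2-yl, with 2 hetero atoms in the ring going to 1, nor pyridin-3-yl to pyridin-2-yl separates these compounds beyond the scatter, so across compounds 1, 2 and 4 the number of ring nitrogens and the choice between the two pyridinyl groups leave no readable mark. No measurement at hand bears on why this place tolerates these exchanges.

Going by these compounds, whether this flat picture holds with tert-butyl on the aromatic carbon remains open, as compound 3 pairs that group only with pyrimidin-2-yl. Also open, on these data alone, is what a phenyl group, with no ring nitrogen, or a pyridinyl group carrying a carboxylic acid would give at this place.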